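The source may report more compounds than this note shows. Statements on the series, on what has been measured and on what is new or still open speak of the compounds shown alone.

In a physicochemical assay for solubility, with a stated time of 18 h, at pH 7.4 (a lower number here means a less soluble compound, a higher number a more soluble compound), compound 1 `CC(C)Cc1ccc2c(NCCCNCc3ccco3)ccnc2c1` gives 4200 nM, level with compound 2 `COc1ccc(F)cc1CNCCCNc1ccnc2cc(Cc3ccc(F)cc3Cl)ccc12` at 4200 nM and compound 3 `COc1ccc(F)cc1CNCCCNc1ccnc2cc(CCC(C)C)ccc12` at 4200 nM. Within the data shown here, the one measured step, no change at the digits printed from compound 2 to compound 3 (within the scatter), swaps a ring for an isobutyl on a saturated chain carbon and leaves the read-out unchanged. Compound 4 `c1ccc(-c2ccc3c(NCCCNCc4ccco4)ccnc3c2)cc1` differs from compound 1 by phenyl in place of isobutyl on an aromatic carbon. Among the measured compounds shown here, no measured pair exchanges isobutyl for phenyl on an aromatic carbon, so the step from compound 2 to compound 3 is the closest guide, and it suggests a small step at most. Compound 1 to compound 4 is therefore expected to give a 1.7-fold lower number from compound 1 to compound 4 (0.23 log units; within the scatter), a modest drop within or near the scatter. Compound 4 is estimated at 2500 nM, with a range from 800 nM to 8000 nM.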

Compound 4, solubility: 32000 nM
Estimate against measurement, compound 4: 13-fold (1.11 log units) below; measured number outside the range, above it.
By their numbers in this assay, from the lowest: compounds 1, 2 and 3 (each within the scatter of the next); then compound 4.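

In this assay, this aromatic carbon proves sensitive to what it carries: phenyl in place of isobutyl gives a 7.6-fold higher number from compound 1 to compound 4 (0.88 log units; beyond the scatter) at this position. The earlier exchange of a ring for isobutyl, on a saturated chain carbon, gave no change at the digits printed from compound 2 to compound 3 (within the scatter) and so gave no hint of this, which shows that a swap at one site cannot be carried over to another. Nothing measured here gives a reason for the step. From the compounds shown here alone, whether an amine, a carboxylic acid or a longer chain at this aromatic carbon would give a similar number remains open, as does whether phenyl would act the same way with the side chain of compound 3.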